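Amidine aryl swaps on the quinone series; alkyl variant pending

A few compounds are considered here, and "the series" means these few. Any claim that something is new, unique, unknown or untested is made for them only; others in the source may bear on it.

Measured compounds in a functional assay on A549 cells (Homo sapiens) for cytotoxicity, read by MTT assay, with a stated time of 48 h; a lower number here means a stronger inhibitor, a higher number a weaker inhibitor:
compound 1 `Cc1ccc(S(=O)(=O)/N=C(/CCNC2=CC(=O)c3ccccc3C2=O)Nc2ccccc2I)cc1`: 24700 nM
compound 2 `COc1ccc(N/C(CCNC2=CC(=O)c3ccccc3C2=O)=N\S(=O)(=O)c2ccc(C)cc2)cc1OC`: 20500 nM
compound 3 `Cc1ccc(S(=O)(=O)/N=C(/CCNC2=CC(=O)c3ccccc3C2=O)Nc2cc(F)c(F)c(F)c2)cc1`: 10200 nM

Compound 3 gives the lowest number of the three, but only its gap to compound 1 is beyond the scatter: a 2.4-fold lower number from compound 1 to compound 3 (0.38 log units; beyond the scatter). Its gap to compound 2 is not: a 2.0-fold lower number from compound 2 to compound 3 (0.30 log units; within the scatter). The swap between the other two is also small: a 1.2-fold lower number from compound 1 to compound 2 (0.08 log units; within the scatter).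

Compound 4 `Cc1ccc(S(=O)(=O)/N=C(/CCNC2=CC(=O)c3ccccc3C2=O)NC(C)C)cc1` differs from compound 3 by isopropyl in place of 3,4,5-trifluorophenyl on an amine nitrogen. Going by the values given here, all three measured steps exchange one aryl group for another on that nitrogen, and none replaces an aryl group with an alkyl group, so no measured step matches this change directly. What the measured steps do show is a narrow span across the three aryl variants. On that basis compound 4 is expected to land within or near the measured span, with no confident direction; the estimated step is a 2.0-fold higher number from compound 3 to compound 4 (0.29 log units; within the scatter). Compound 4 is estimated at 20000 nM, with a range from 8000 nM to 50000 nM.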

Compound 4, half-maximal inhibitory concentration: 44300 nM
For compound 4 the middle estimate is 2.2-fold (0.35 log units) below the measured one; measured number inside the range.
By their numbers in this assay, from the lowest: compounds 3, 2, 1 and 4 (each within the scatter of the next, the first and the last beyond it).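

In this assay, going by these compounds alone, isopropyl is the only alkyl group on this amine nitrogen and gives the largest step so far (a 4.3-fold higher number from compound 3 to compound 4 (0.64 log units; beyond the scatter)). Within the data shown here, the step from the dimethoxy analogue also stands clear (a 2.2-fold higher number from compound 2 to compound 4 (0.33 log units; beyond the scatter)), but the one from the iodo analogue does not (a 1.8-fold higher number from compound 1 to compound 4 (0.25 log units; within the scatter)). The same change therefore reads differently depending on which aryl group leaves, and isopropyl separates from only two of the three aryl variants.

No measurement shown explains these steps.

Going by these compounds, with a single alkyl example, it remains open whether these steps belong to alkyl groups in general or to isopropyl alone. A cyclohexyl ring, a benzyl group or a longer chain such as n-butyl on this nitrogen would test that.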